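This account rests on a few compounds, and the source may have more. Where it says the series, first, only, none or still open, it means among the compounds named here.

Of the compounds shown here, three built on one shared core have been measured in an assay on isolated protein for inhibition of Leucine-rich repeat serine/threonine-protein kinase 2 (Homo sapiens), read by TR-FRET and LanthaScreen, with stated times of 50 min and 30 min, in the presence of a further agent that is not named here; a higher number here means a weaker inhibitor, a lower number a stronger inhibitor. Compound 1 `C[C@@H]1CCCN1c1c(C#N)c2c(N)nc(Nc3cn[nH]c3)nc2n1C` gives 6 nM in this assay, the lowest of the three numbers. Compound 2 `Cc1c(Nc2nc(N)c3c(C#N)c(N4CCC[C@H]4C)n(C)c3n2)cnn1[C@H]1CCOC1` gives 23 nM in this assay, and compound 3 `Cc1c(Nc2nc(N)c3c(C#N)c(N4CCC[C@H]4C)n(C)c3n2)cnn1CC1(O)COC1` gives 16 nM. Compound 1 stands beyond the scatter from both, with compound 3 nearer to it and compound 2 further away. Within the data shown here, the single measured step, a 1.4-fold lower number from compound 2 to compound 3 (0.16 log units; within the scatter), concerns the group on an aromatic nitrogen and lies within the scatter. Compound 4 `Cc1n[nH]cc1Nc1nc(N)c2c(C#N)c(N3CCC[C@H]3C)n(C)c2n1` has not been measured. It differs from compound 1 by methyl in place of hydrogen on an aromatic carbon. Among the measured compounds shown here, no measured pair isolates this change: compound 2 and compound 3 carry the methyl on the aromatic carbon, but each also carries a group on an aromatic nitrogen that compound 1 and compound 4 lack, so their higher numbers cannot be attributed to the methyl alone. The step of a 1.7-fold higher number from compound 1 to compound 4 (0.22 log units; within the scatter) is therefore expected to be small, most likely toward a somewhat higher number, possibly none beyond the scatter. Compound 4 is estimated at 10 nM, within a range from 4 nM to 25 nM.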

Compound 4, half-maximal inhibitory concentration: 42 nM
Beside the measured number, compound 4's estimate is 4.2-fold (0.62 log units) below it; the measured number lies above the stated range.
By their numbers in this assay, from the lowest: compound 1; then compounds 3, 2 and 4 (each within the scatter of the next, the first and the last beyond it).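

The pair compound 1 and compound 4 isolates the methyl on the aromatic carbon of the five-membered ring, and in this assay the step is a 7.0-fold higher number from compound 1 to compound 4 (0.85 log units; beyond the scatter), so this one heavy atom, on a carbon next to the ring atom that bears a large group, is enough to move the number beyond the scatter. Compound 2, which keeps the methyl and adds oxolan-3-yl on an aromatic nitrogen, gives 23 nM, within the scatter of compound 4, so much of its distance from compound 1 can be read at the methyl itself. Nothing given here bears on why the methyl has this effect.

The compounds shown hold only hydrogen or methyl on this carbon, so what an ethyl, a chlorine or a methoxy would do there stays open. Also open, as far as these compounds go, is how oxolan-3-yl on the aromatic nitrogen would read with hydrogen on this carbon.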